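The source may hold more compounds than are shown below. What is called first, only, known or untested is meant among the compounds shown, and "the series" means these compounds.

Measured so far:
compound 1, `Nc1scc(-c2ccccc2)c1C(=O)c1ccccc1` — 48%
compound 2, `Nc1scc(-c2ccc([N+](=O)[O-])cc2)c1C(=O)c1ccccc1` — 47%

Of the compounds shown here, two with a shared core have been measured in a functional assay on CHO cells for agonist activity at adenosine receptor A1 (Homo sapiens), read by fluorescence and ERK phosphorylation, with stated times of 30 min and 1.5 h, tested at 10 uM; on this read-out lower numbers stand for a weaker effect and higher numbers for a stronger effect at the one concentration tested. Compound 1 `Nc1scc(-c2ccccc2)c1C(=O)c1ccccc1` gives 48% in this assay. Compound 2 `Nc1scc(-c2ccc([N+](=O)[O-])cc2)c1C(=O)c1ccccc1` gives 47% in this assay. Going by the values given here, the only measured step is a number 1 percentage points lower from compound 1 to compound 2 (within the scatter), nitro in place of hydrogen on an aromatic carbon; the two numbers sit within the scatter of each other, so neither compound can be set apart from the other on this read-out.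

Compound 3 `COc1ccc(-c2csc(N)c2C(=O)c2ccccc2)cc1` has not yet been measured in this assay. It differs from compound 2 in one place: methoxy in place of nitro on an aromatic carbon. Among the compounds with values here, the single measured step, a number 1 percentage points lower from compound 1 to compound 2 (within the scatter), bears on this change only indirectly: it shows that putting nitro at this place, para to a large group, left the read-out unchanged beyond the scatter. Within the data shown here, no measured step shows methoxy at this place, so the expectation rests on thin ground. Because a number 1 percentage points lower from compound 1 to compound 2 (within the scatter) was within the scatter, compound 3 is expected to show no change at the digits printed from compound 2 to compound 3 (within the scatter), no step beyond the scatter. Compound 3 is therefore estimated at 47%, with a range from 32% to 62%.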

Compound 3, a percentage reported as activity, at one concentration (the size of the read-out at that concentration, not a potency): 52%
Beside the measured number, compound 3's estimate is 5 percentage points below it; the range from low to high includes it.
By their numbers in this assay, from the lowest: compounds 2, 1 and 3 (each within the scatter of the next).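

In this assay, methoxy in place of nitro on an aromatic carbon, para to a large group, gives a number 5 percentage points higher from compound 2 to compound 3 (within the scatter) and methoxy in place of hydrogen at the same place gives a number 4 percentage points higher from compound 1 to compound 3 (within the scatter). Hydrogen, nitro and methoxy have now all been seen at this position, and no step among these three compounds goes beyond the scatter, so this read-out cannot set any of the three groups apart. No measurement offers a cause for this result or tells what these groups do at this position.

These numbers each come from a single concentration and are not potencies, so they leave open whether the three compounds would differ if full concentration-response curves were compared. As far as these compounds go, it also remains open whether a different group at this position, such as an amine, a carboxylic acid or a longer chain like butoxy, would produce a step beyond the scatter, and whether methoxy would give the same result at another place on this ring.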